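From Trifluoromethoxy to Trifluoromethyl: A Small Swap

The source may report more compounds than this note shows. Statements on the series, on what has been measured and on what is new or still open speak of the compounds shown alone.

Compound 1 (`OC[C@@H]1[C@@H](O)[C@H](O)[C@@H](O)CN1CCCCCCOc1ccc(OC(F)(F)F)cc1`): > 500000 nM
Compound 2 (`OC[C@@H]1[C@@H](O)[C@H](O)[C@@H](O)CN1CC/C=C/CCOc1cc(F)ccc1F`): > 500000 nM
Compound 3 (`OC[C@@H]1[C@@H](O)[C@H](O)[C@@H](O)CN1CCCCCCOc1cc(F)ccc1F`): > 500000 nM

These three results come from an ADME assay on BHK cells (Mesocricetus auratus) for cytotoxicity, read by MTT assay (a lower number here means that less compound is tolerated, a higher number that more compound is tolerated), and none of them is an exact number. Compound 1 stands at a limit of the assay (> 500000 nM) and not at a measured value. Within the data shown here, the other two compounds stand at the same limit (the limit of > 500000 nM in this assay, at which 3 of the 3 values shown sit), so the set offers no measured step to learn from.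

Compound 4 (`OC[C@@H]1[C@@H](O)[C@H](O)[C@@H](O)CN1CCCCCCOc1ccc(C(F)(F)F)cc1`) keeps the shared core and the chain of compound 1 and differs in one place. It carries trifluoromethyl in place of trifluoromethoxy on an aromatic carbon, para to a large group (trifluoromethyl in place of trifluoromethoxy on an aromatic carbon).

Compound 1 is the only anchor for an expectation, and its value is a limit (> 500000 nM). In this assay no step beyond the usual scatter is expected in either direction, with an estimated size of (a number no higher from compound 1 to compound 4 (the limit leaves the size open)). Another limit is the likeliest report. The estimated value for compound 4 is 500000 nM with an expected range of (300000 nM to 800000 nM).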

Compound 4, half-maximal cytotoxic concentration: 470000 nM
For compound 4 the middle estimate is 1.1-fold (0.03 log units) above the measured one, within the range that was stated.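

Among these compounds, compound 4 gives the first exact number in this assay, so this position on an aromatic carbon, para to a large group, now has a reading that is not a limit. Placing trifluoromethyl in place of trifluoromethoxy there gives an at least 1.0-fold lower number from compound 1 to compound 4 (0.02 log units; that floor lies within the scatter), so the printed floor alone does not show a change beyond the usual scatter. The full size of the step stays unknown because compound 1 is reported only as a limit, as are most of the compounds shown: the limit of > 500000 nM in this assay, at which 3 of the 4 values shown sit.

From the compounds shown here alone, it remains open how an amine or a carboxylic acid at this same aromatic carbon would read in this assay. Going by these compounds, a longer chain in place of the chain of compound 4 is equally open, and it could show whether that part of the compound moves the number.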